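Geometric Isomer of a Thiophene Acid: Expectation Before Measurement

This account rests on a few compounds, and the source may have more. Where it says the series, first, only, none or still open, it means among the compounds named here.

Measured so far in an assay (Equus caballus) for inhibition of Thromboxane-A synthase (Homo sapiens), using microsomes; on this read-out lower numbers stand for stronger inhibition and higher numbers for weaker inhibition:
compound 1 `C/C(=C\CCCCC(=O)O)c1cccnc1` gives 210 nM
compound 2 `O=C(O)CCCC/C=C(\c1cccnc1)c1ccsc1` gives 31 nM
compound 3 `O=C(O)CCCC/C=C(/c1ccc(F)cc1)c1cccnc1` gives 83 nM

Compound 2 has the lowest number of the three in this assay. Its nearest neighbour is compound 3, with a 2.7-fold higher number from compound 2 to compound 3 (0.43 log units; beyond the scatter). Compound 1 stands furthest away, and its value in this assay, 210 nM, lies well above that of compound 2.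

Compound 4 `O=C(O)CCCC/C=C(/c1cccnc1)c1ccsc1` has not yet been measured. Its relation to compound 2 is this: the two compounds have the same atoms and bonds and differ only in configuration as drawn: 1 of 1 stereo elements differ; a double bond is drawn E in compound 2 and Z in compound 4. Nothing is added or removed; only the drawn geometry of the double bond changes.

For the measured compounds named here, none of the measured steps bears on this change. Going by the values given here, the one step for which two compounds differ in a single place, a 2.7-fold higher number from compound 2 to compound 3 (0.43 log units; beyond the scatter), exchanges one aromatic group for another and says nothing about double-bond geometry. Compound 1 differs from compound 2 in more than one place and is of no help either. Among the compounds with values here, the expectation for compound 4 therefore rests on no measured precedent, and is set as no step beyond the scatter, with a wide range to allow for either direction. The expected change is a 1.6-fold higher number from compound 2 to compound 4 (0.21 log units; within the scatter). Compound 4 is estimated at 50 nM, within 15 nM to 200 nM.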

Compound 4, half-maximal inhibitory concentration: 62 nM
Compound 4: middle estimate off by 1.2-fold (0.09 log units), on the low side; low and high end bracket the measured number.
By their numbers in this assay, from the lowest: compounds 2, 4 and 3 (each within the scatter of the next, the first and the last beyond it); then compound 1.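

Compound 4 gives the first direct reading of double-bond geometry among these compounds, and the comparison is a clean one: the fact that compounds 2 and 4 differ only in the configuration as drawn. In this assay, drawing the double bond Z instead of E amounts to a 2.0-fold higher number from compound 2 to compound 4 (0.30 log units; within the scatter), so with thiophen-3-yl in place the two geometries cannot be told apart beyond the usual scatter. Compound 4 also links compound 1 to the thiophene series through a change in one place, which compound 2 could not do, and thiophen-3-yl in place of methyl gives a 3.4-fold lower number from compound 1 to compound 4 (0.53 log units; beyond the scatter), a modest step that does lie beyond the scatter.

Whether geometry stays this unobtrusive with other groups on the double-bonded carbon remains open, since the reading comes from one pair only and neither the 4-fluorophenyl compound 3 nor the methyl compound 1 has a geometric partner among the compounds shown. Also open, from the compounds shown here alone, is how ethyl, unsubstituted phenyl or furan-3-yl would compare at this position, and whether a shorter or longer chain leading to the carboxylic acid would change the picture for either geometry.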